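The compounds below may be only part of what the source reports. "The series", "measured", "known", "first", "only" and "open" are said of these compounds alone.

Working notes on the series. Compound 1 `O=C(/C=C/c1ccccc1)c1ccc(N2C(=O)C=CC2=O)cc1` is the parent without a substituent on the outer ring; in a functional assay on CCRF-CEM cells (Homo sapiens) for cytotoxicity (a higher number here means a weaker inhibitor, a lower number a stronger inhibitor), compound 1 gives 9800 nM. Among the measured compounds shown here, compound 2 `Cc1ccc(/C=C/C(=O)c2ccc(N3C(=O)C=CC3=O)cc2)cc1` carries a methyl on that ring and in this assay gives 4100 nM, the lowest of the two numbers so far; the change from the parent brought a 2.4-fold lower number from compound 1 to compound 2 (0.38 log units; beyond the scatter), a modest gain. Compound 3 `O=C(/C=C/c1ccc([N+](=O)[O-])cc1)c1ccc(N2C(=O)C=CC2=O)cc1` differs from compound 2 by nitro in place of methyl on an aromatic carbon. For the measured compounds named here, no measured step exchanges a methyl for a nitro; the only step at hand, a 2.4-fold lower number from compound 1 to compound 2 (0.38 log units; beyond the scatter), concerns methyl replacing hydrogen and bears on the new change only in showing that a substituent on that ring moved the number modestly. Direction and size for a nitro are not set by anything measured, so in this assay the expected step is a 1.2-fold higher number from compound 2 to compound 3 (0.09 log units; within the scatter), small and uncertain. Compound 3 is therefore estimated at 5000 nM in this assay, within 1500 nM to 16000 nM.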

Compound 3, half-maximal inhibitory concentration: > 500000 nM
Compound 3: only a limit was reported; the forecaster's own chance of this, stated with the estimate: 5%; at least 100-fold (2.00 log units) between middle value and limit.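

In this assay compound 3 carries only a limit, not a number: the limit of > 500000 nM in this assay, at which 1 of the 3 values shown sits. Exchanging methyl for nitro on this aromatic carbon, para to a large group, gives an at least 120-fold higher number from compound 2 to compound 3 (2.08 log units; beyond the scatter), and against the unsubstituted parent the nitro gives an at least 51-fold higher number from compound 1 to compound 3 (1.70 log units; beyond the scatter). The earlier methyl step suggested a position that moves the number only modestly, whereas these steps show that a substituent here can also shift it sharply the other way, with the full size hidden behind the limit.

The three compounds do not tell whether an amine, a methoxy or a chlorine on this carbon would follow methyl or nitro. They also give no cause for the loss, and they leave open whether it belongs to nitro alone.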